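Extending the nitrogen substituent of compound 2 with methoxymethyl

A few compounds are considered here, and "the series" means these few. Any claim that something is new, unique, unknown or untested is made for them only; others in the source may bear on it.

Measured compounds:
compound 1 `CCc1nc2c(-c3ccc(Cl)cc3Cl)ccnc2n1[C@H](CC)C1CC1` — 0.2 nM
compound 2 `CCc1nc2c(-c3ccc(Cl)cc3Cl)ccnc2n1C(C)C1CCC1` — 1 nM
compound 3 `CCCC(C)n1c(CC)nc2c(-c3ccc(S(C)(=O)=O)cc3C(F)(F)F)ccnc21` — 6.8 nM

Compound 2 `CCc1nc2c(-c3ccc(Cl)cc3Cl)ccnc2n1C(C)C1CCC1` sits second highest of the three numbers in an assay for binding affinity to Corticotropin releasing factor receptor (Rattus norvegicus) (a higher number here means a weaker inhibitor, a lower number a stronger inhibitor), where compound 2 gives 1 nM. Compound 1 `CCc1nc2c(-c3ccc(Cl)cc3Cl)ccnc2n1[C@H](CC)C1CC1` gives 0.2 nM in this assay, and the step of a 5.0-fold higher number from compound 1 to compound 2 (0.70 log units; beyond the scatter) shows that swapping the group on the aromatic nitrogen moves the number modestly but beyond the scatter. Compound 3 `CCCC(C)n1c(CC)nc2c(-c3ccc(S(C)(=O)=O)cc3C(F)(F)F)ccnc21` gives 6.8 nM in this assay; it differs from compound 2 in more than one place, so its value only shows that a longer chain on the nitrogen is compatible with binding at that level.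

Compound 4 `CCc1nc2c(-c3ccc(Cl)cc3Cl)ccnc2n1C(CCOC)C1CCC1` is derived from compound 2 by methoxymethyl in place of hydrogen on a saturated chain carbon, two bonds along the chain from an aromatic nitrogen and a saturated ring carbon. Among the measured compounds shown here, no measured step covers this change itself; the step from compound 1 to compound 2 is the only one touching this position and was modest. Compound 4 is therefore expected to lie near compound 2, with a small weakening at most, as a 2.0-fold higher number from compound 2 to compound 4 (0.30 log units; within the scatter). The estimate for compound 4 in this assay is 2 nM, within 0.5 nM to 8 nM.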

Compound 4, inhibition constant: 2.4 nM
For compound 4 the middle estimate is 1.2-fold (0.08 log units) below the measured one; the measured number falls inside the stated range.
By their numbers in this assay, from the lowest: compound 1; then compound 2; then compound 4; then compound 3.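

In this assay, the step of a 2.4-fold higher number from compound 2 to compound 4 (0.38 log units; beyond the scatter) shows that the saturated chain carbon, two bonds along the chain from an aromatic nitrogen and a saturated ring carbon, takes methoxymethyl at a modest cost that still lies beyond the scatter. Among the compounds shown here, compound 4 is also the first here with oxygen in the group on this nitrogen, the earlier compounds holding only carbon there. Measured against the 1-cyclopropylpropyl group, the change is large, with the step of a 12-fold higher number from compound 1 to compound 4 (1.08 log units; beyond the scatter) exceeding a 5.0-fold higher number from compound 1 to compound 2 (0.70 log units; beyond the scatter) for the shorter 1-cyclobutylethyl group. No evidence is available to explain these steps.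

The compounds shown leave open whether a plain propyl chain on this carbon would read like the 2-methoxyethyl chain, and so whether the oxygen or the chain length carries the step. From the compounds shown here alone, how a terminal amine or carboxylic acid on this chain would read is equally open.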